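The source may report more compounds than this note shows. Statements on the series, on what has been measured and on what is new or still open speak of the compounds shown alone.

For the measured compounds named here, compound 2 `O=C(Nc1cccc(Cl)c1)O/N=C(\C1CCCCC1)C(Cc1ccncc1)C1CCCCC1` is the only compound with a numbered result here: in an assay on isolated protein for displacement of a labelled ligand from metabotropic glutamate receptor 5 (Rattus norvegicus) (on this read-out higher numbers stand for weaker inhibition and lower numbers for stronger inhibition), compound 2 gives 117 nM. Compound 1 `O=C(Nc1ccccc1)O/N=C(\C1CCCCC1)C(CN1CCc2ccccc2C1)C1CCCCC1` sits at a limit of this assay rather than a number, with > 1000 nM, the limit described as the limit of > 1000 nM in this assay, at which 1 of the 2 values shown sits. Compound 3 `O=C(Nc1cccc(Cl)c1)O/N=C(\C1CCCCC1)C(Cc1cc[nH]c1)C1CCCCC1` differs from compound 2 by 1H-pyrrol-3-yl in place of pyridin-4-yl on a saturated chain carbon, two bonds along the chain from a carbon with a double bond to nitrogen and a saturated ring carbon. Going by the values given here, no measured pair shows the effect of such a swap, so the size of the step of a 2.1-fold higher number from compound 2 to compound 3 (0.33 log units; beyond the scatter) is an estimate only, leaning toward modest weakening. Compound 3 is thus expected to give about 250 nM in this assay, somewhere between 60 nM and 1000 nM.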

Compound 3, inhibition constant: 16.1 nM
Compound 3: middle estimate off by 16-fold (1.19 log units), on the high side, outside the stated range (below it).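

In this assay, the group on this saturated chain carbon clearly matters: going to 1H-pyrrol-3-yl gives a 7.3-fold lower number from compound 2 to compound 3 (0.86 log units; beyond the scatter) and so strengthens inhibition. The pyridin-4-yl ring is therefore not required here, and a five-membered aromatic ring with a hydrogen-bond donor instead of an acceptor works better. Nothing measured here explains this gain.

The compounds shown leave open whether ring size or the donor accounts for the step. A furan-3-yl or 1-methylpyrrol-3-yl group at this position would help separate the two.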